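Guanidine on the Ring Amine: Expected Tolerance in Cells

This account rests on a few compounds, and the source may have more. Where it says the series, first, only, none or still open, it means among the compounds named here.

Compound 1, `C1=C[C@H]2[C@H]3[C@H]4[C@@H]1[C@@H]1[C@H]2[C@@H]2[C@H]3[C@@H]3CNC[C@@H]3[C@H]4[C@H]12`: 20000 nM
Compound 2, `C1C[C@H]2[C@H]3[C@H]4[C@@H]1[C@@H]1[C@H]2[C@@H]2[C@H]3[C@@H]3CNC[C@@H]3[C@H]4[C@H]12`: 4000 nM

In an ADME assay on MDCK cells (Canis lupus familiaris) for cytotoxicity, with a stated time of 72 h (a lower number here means that less compound is tolerated, a higher number that more compound is tolerated), compound 2 gives 4000 nM, the lowest of the two numbers shown. Compound 1 gives 20000 nM, a higher number by a margin beyond the usual scatter. Compound 3, `N=C(N)N1C[C@@H]2[C@H](C1)[C@@H]1[C@@H]3[C@H]4CC[C@H]5[C@@H]3[C@H]2[C@H]2[C@@H]5[C@@H]4[C@@H]12`, differs from compound 2 by a group of 3 heavy atoms (1 carbon, 2 nitrogen; no ring) in place of a hydrogen atom, on an amine nitrogen in a ring. Going by the values given here, no step between two measured compounds shows what such a change does in this assay. The step from compound 2 to compound 3 is expected to be modest, a 1.5-fold higher number from compound 2 to compound 3 (0.18 log units; within the scatter), without a direction that clearly exceeds the scatter. Compound 3 is therefore estimated at 6000 nM, within a range from 1500 nM to 25000 nM.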

Compound 3, minimum cytotoxic concentration: 7000 nM
For compound 3 the middle estimate is 1.2-fold (0.07 log units) below the measured one; low and high end bracket the measured number.
By their numbers in this assay, from the lowest: compounds 2 and 3 (each within the scatter of the next); then compound 1.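

In this assay, the first step measured at this position, a group of 3 heavy atoms (1 carbon, 2 nitrogen; no ring) in place of a hydrogen atom on an amine nitrogen in a ring, gives a 1.8-fold higher number from compound 2 to compound 3 (0.24 log units; within the scatter). Tolerance in these cells therefore does not separate compound 2 and compound 3, so this amine nitrogen accepts this group without a difference beyond the scatter. Nothing available explains this result.

As far as these compounds go, whether a carboxylic acid or a longer chain on the same nitrogen would also stay within the scatter remains open. So does whether this group would behave alike on the core of compound 1.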